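This account rests on a few compounds, and the source may have more. Where it says the series, first, only, none or still open, it means among the compounds named here.

Among the measured compounds shown here, in a functional assay (trachea) with Cavia porcellus as the target (on this read-out higher numbers stand for weaker inhibition and lower numbers for stronger inhibition), compound 2 `CCn1nc(-n2cncn2)c2ccccc2c1=O` gives 15800 nM, the higher of the two numbers so far, while compound 1 `CCn1nc(-n2ccnc2)c2ccccc2c1=O` gives 5370 nM. Compound 3 `CCn1nc(-c2nccs2)c2ccccc2c1=O` alters one group on the shared core, with 1,3-thiazol-2-yl in place of 1H-1,2,4-triazol-1-yl on an aromatic carbon. For the measured compounds named here, the only measured swap of one such ring for another is a 2.9-fold higher number from compound 1 to compound 2 (0.47 log units; beyond the scatter), a modest step. A step of similar or smaller size is therefore expected in this assay, tentatively toward a lower number. The expected change is a 1.8-fold lower number from compound 2 to compound 3 (0.24 log units; within the scatter). For compound 3 the estimated value is 9000 nM, with an expected range of 3000 nM to 27000 nM.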

Compound 3, half-maximal inhibitory concentration: 3160 nM
Compound 3: the middle estimate sits 2.8-fold (0.45 log units) above what was measured, and the stated range covers the measured number.
By their numbers in this assay, from the lowest: compounds 3 and 1 (each within the scatter of the next); then compound 2.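

In this assay, 1,3-thiazol-2-yl in place of 1H-1,2,4-triazol-1-yl gives a 5.0-fold lower number from compound 2 to compound 3 (0.70 log units; beyond the scatter), a second ring swap at this position that lies beyond the scatter. In contrast, a 1.7-fold lower number from compound 1 to compound 3 (0.23 log units; within the scatter) leaves 1,3-thiazol-2-yl and 1H-imidazol-1-yl indistinguishable, so among these three rings only 1H-1,2,4-triazol-1-yl stands apart. Nothing available explains this difference. Going by these compounds, all three groups here are five-membered aromatic rings, so it remains open how this position would respond to an amine or a phenyl ring.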